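Fluoro on the benzoyl phenyl: working notes

The compounds below may be only part of what the source reports. "The series", "measured", "known", "first", "only" and "open" are said of these compounds alone.

Measured so far in a functional assay on Ehrlich cells (Mus musculus) for cytotoxicity, read by MTT assay, with a stated time of 48 h; on this read-out higher numbers stand for weaker inhibition and lower numbers for stronger inhibition:
compound 1 `Cc1cc(C(=O)c2ccccc2)ccc1OCC(=O)Nc1nc(-c2ccccc2)cs1` gives 24000 nM
compound 2 `COc1ccc(-c2csc(NC(=O)COc3ccc(C(=O)c4ccccc4)cc3C)n2)cc1` gives 28400 nM

Among the compounds with values here, compound 2 carries the methoxy on the phenyl attached to the thiazole; the only measured step in the set, a 1.2-fold higher number from compound 1 to compound 2 (0.07 log units; within the scatter), lies within the scatter, so compound 2 and compound 1 cannot be told apart on this read-out. Compound 2 thus stands where compound 1 stands, in the low micromolar region of this assay.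

Compound 3 `COc1ccc(-c2csc(NC(=O)COc3ccc(C(=O)c4ccc(F)cc4)cc3C)n2)cc1` differs from compound 2 in one place: fluoro in place of hydrogen on an aromatic carbon. Within the data shown here, no measured step touches the benzoyl phenyl; the one step known, the methoxy addition on the other phenyl, was small, a 1.2-fold higher number from compound 1 to compound 2 (0.07 log units; within the scatter), and says nothing direct about a fluoro on the carbonyl-bearing ring. Among the measured compounds shown here, with no bearing step and a single small group added, no change beyond the scatter is expected for compound 3 in this assay, and the step expected from compound 2 to compound 3 is a 1.0-fold lower number from compound 2 to compound 3 (0.01 log units; within the scatter). Compound 3 is estimated at 28000 nM, within 14000 nM to 56000 nM.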

Compound 3, half-maximal inhibitory concentration: 5400 nM
The estimate for compound 3 lay 5.2-fold (0.71 log units) above the measured number; measured number below the stated range.
By their numbers in this assay, from the lowest: compound 3; then compounds 1 and 2 (each within the scatter of the next).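

In this assay, the change from benzoyl to (4-fluorophenyl)carbonyl gives a 5.3-fold lower number from compound 2 to compound 3 (0.72 log units; beyond the scatter), which makes the benzoyl phenyl a place where one added fluorine atom moves the number beyond the scatter, towards stronger inhibition. Within the data shown here, the only earlier step, the methoxy on the other phenyl, stayed within the scatter at a 1.2-fold higher number from compound 1 to compound 2 (0.07 log units; within the scatter), so this is the first one-place change that separates two compounds on this read-out. No measurement at hand bears on why the step has this size.

Among these compounds, whether the fluoro gives a step of similar size on compound 1, which lacks the methoxy, remains open, so the step is tied for now to the single pair of compound 2 and compound 3. Also open, from the compounds shown here alone, is whether the step is particular to fluoro or would appear with chloro, a hydroxyl or an amine at the same aromatic carbon, para to a large group, and whether a second fluoro on that ring would move the number further.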